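The source may report more compounds than this note shows. Statements on the series, on what has been measured and on what is new or still open speak of the compounds shown alone.

Of the compounds shown here, two have so far been measured in a functional assay on the whole organism (blood) with Rattus norvegicus as the target, with stated times of 24 h and 1 h, at a dose of 5 mg/kg by the intraperitoneal route; a higher number here means a stronger effect of the compound at the dose given, a lower number a weaker effect. Compound 1 `COc1ccc(Cl)cc1C(=O)NCCC1CCN(S(=O)(=O)NC(=O)NC2CCCCC2)CC1` gives 25%. Among the compounds with values here, compound 2 `CCCNC(=O)NS(=O)(=O)N1CCC(CCNC(=O)c2cc(Cl)ccc2OC)CC1` gives 11%, the lower of the two numbers, and the single measured step, a number 14 percentage points lower from compound 1 to compound 2 (beyond the scatter), separates them. Compound 3 `COc1ccc(NC(=O)NS(=O)(=O)N2CCC(CCNC(=O)c3cc(Cl)ccc3OC)CC2)cc1` differs from compound 2 by 4-methoxyphenyl in place of propyl on an amide-type nitrogen. That one earlier step, at this same amide-type nitrogen, saw propyl replace cyclohexyl and the number fall; here propyl gives way to 4-methoxyphenyl, so a rise of similar size is expected, about a number 11 percentage points higher from compound 2 to compound 3 (beyond the scatter). Compound 3 is accordingly estimated at 22%, with a range from 8% to 38%.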

Compound 3, a percentage reported as activity, at one dose (the size of the read-out at that dose, not a potency): 27%
The estimate for compound 3 lay 5 percentage points below the measured number; low and high end bracket the measured number.
By their numbers in this assay, from the lowest: compound 2; then compounds 1 and 3 (each within the scatter of the next).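

Compound 3 shows that this amide-type nitrogen can carry an aromatic ring: 4-methoxyphenyl in place of propyl gives a number 16 percentage points higher from compound 2 to compound 3 (beyond the scatter) and restores the level seen with cyclohexyl, with 4-methoxyphenyl in place of cyclohexyl giving a number 2 percentage points higher from compound 1 to compound 3 (within the scatter) as the comparison. Among these three compounds, the two ring-bearing groups stand level and the open propyl chain stands apart. Nothing available explains this difference.
Still open, from the compounds shown here alone, is what the methoxy group contributes, which a plain phenyl would test. Also open, going by these compounds, is whether a methyl or a chain ending in an amine would behave like propyl or like the rings.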